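A few compounds are considered here, and "the series" means these few. Any claim that something is new, unique, unknown or untested is made for them only; others in the source may bear on it.

Compound 1 `C/C=C\C[C@@H](C)C[C@@H](C)/C(O)=C1/C(=O)N/C(=C\c2ccc(O)cc2)C1=O` in a functional assay on MDA-MB-231 cells (Homo sapiens) for inhibition, read by MTT assay, with a stated time of 48 h (a lower number here means a stronger inhibitor, a higher number a weaker inhibitor), reaches only the limit > 40000 nM.
Compound 2 `Cc1cc(O)c2oc(=O)c(O)c(-c3ccc(O)cc3)c2c1` in this assay likewise reaches only the limit > 40000 nM.
Compound 3 `C=C[C@@H]1C[C@H](C)C[C@H](C)C1c1c(O)ccn(O)c1=O` in this assay gives 1630 nM.

Among the three measured compounds, compound 3 is the only one with a measured number; the other two sit at the limit of > 40000 nM in this assay, at which 2 of the 3 values shown sit, so no ordering among them can be read from these data. Compound 4 `C=C[C@@H]1C[C@H](C)C[C@H](C)C1c1c(O)cc[nH]c1=O` differs from compound 3 by hydrogen in place of hydroxy on an aromatic nitrogen. Among the compounds with values here, no pair of measured compounds differs in one place, so the size of such a step has not been seen here. Compound 4 is nevertheless expected to be weaker than compound 3, with the step of a 3.7-fold higher number from compound 3 to compound 4 (0.57 log units; beyond the scatter) expected to go beyond the usual scatter. Compound 4 is estimated at 6000 nM, within a range from 1500 nM to 30000 nM.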

Compound 4, half-maximal inhibitory concentration: > 40000 nM
Compound 4: no number, only a limit; the forecaster's own chance of this, stated with the estimate: 20%; middle value at least 6.6-fold (0.82 log units) from the limit.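

In this assay, within the data shown here, the swap of hydroxy for hydrogen on the aromatic nitrogen gives the first step that can be read: an at least 24-fold higher number from compound 3 to compound 4 (1.38 log units; beyond the scatter). Compound 4 gives only a limit of the assay, > 40000 nM, and not a number. For this pair, a measurable number depends on keeping the hydroxy, and without it compound 4 joins the others at the limit: the limit of > 40000 nM in this assay, at which 3 of the 4 values shown sit.

As far as these compounds go, the true size of the step stays unknown past that limit. From the compounds shown here alone, whether a methoxy group or an amine on this nitrogen would keep the activity of compound 3 also remains open.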